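Cyclohexyl ether in place of pyridyl ether: cytotoxicity

A few compounds are considered here, and "the series" means these few. Any claim that something is new, unique, unknown or untested is made for them only; others in the source may bear on it.

Measured compounds:
compound 1 `Cc1cccc(Oc2cccc(CN3CCC(n4cc(C)c(=O)[nH]c4=O)CC3)c2)c1`: > 64000 nM
compound 2 `Cc1cn(C2CCN(Cc3cccc(Oc4cccnc4)c3)CC2)c(=O)[nH]c1=O`: > 64000 nM
compound 3 `Cc1cn(C2CCN(Cc3cccc(Oc4ccccn4)c3)CC2)c(=O)[nH]c1=O`: > 64000 nM

In an ADME assay on MRC5 cells (Homo sapiens) for cytotoxicity, read by fluorescence and resazurin assay, with a stated time of 3 days (a lower number here means a stronger inhibitor, a higher number a weaker inhibitor), compound 1 gives > 64000 nM, which is a limit of the assay and not a number. Compound 2 likewise gives > 64000 nM, again a limit. Compound 3 stands at > 64000 nM, also a limit, so its position on the numbers is known only as a boundary; all three values share (the limit of > 64000 nM in this assay, at which 3 of the 3 values shown sit). The measured steps are therefore unreadable: a step that the two limits leave unreadable from compound 1 to compound 2, a step that the two limits leave unreadable from compound 1 to compound 3 and a step that the two limits leave unreadable from compound 2 to compound 3 cannot be sized, because both ends sit at the limit (the limit of > 64000 nM in this assay, at which 3 of the 3 values shown sit).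

Compound 4 `Cc1cn(C2CCN(Cc3cccc(OC4CCCCC4)c3)CC2)c(=O)[nH]c1=O` is not yet measured. It differs from compound 3 by cyclohexyl in place of pyridin-2-yl on an oxygen on an aromatic ring. Among the compounds with values here, no measured step bears readably on this change, since every step runs between two limits. Within the data shown here, the only guidance is that exchanges of the group on the oxygen on the aromatic ring, from compound 1 through compound 3, have not moved any value below the limit.

Compound 4 is therefore estimated at 80000 nM, with a range from 30000 nM to 250000 nM. The step this expectation implies, a step that the limit leaves unreadable from compound 3 to compound 4, is expected to be none beyond the scatter, with the result most likely reported again as a limit.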

Compound 4, half-maximal inhibitory concentration: 23600 nM
Compound 4: middle estimate off by 3.4-fold (0.53 log units), on the high side, outside the stated range (below it).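

In this assay, cyclohexyl is the only group on the oxygen on the aromatic ring among those shown that brings a value inside the measurable range: compound 4 gives 23600 nM. Replacing each aromatic group with cyclohexyl gives an at least 2.7-fold lower number from compound 3 to compound 4 (0.43 log units; beyond the scatter), an at least 2.7-fold lower number from compound 2 to compound 4 (0.43 log units; beyond the scatter) and an at least 2.7-fold lower number from compound 1 to compound 4 (0.43 log units; beyond the scatter), while the steps among compound 1, compound 2 and compound 3 cannot be read. Each new step gives only a minimum size, because one end of it sits at a limit of the assay: the limit of > 64000 nM in this assay, at which 3 of the 4 values shown sit.

The compounds shown leave open whether the change follows from losing the aromatic ring or from cyclohexyl itself, a question that a cyclopentyl group, a piperidine ring or a butyl chain on the same oxygen would help to settle. From the compounds shown here alone, the true size of all three steps also remains open.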